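Notes on compound 4 against compound 2 and compound 3

The source may report more compounds than this note shows. Statements on the series, on what has been measured and on what is new or still open speak of the compounds shown alone.

Three compounds of the series have numbers in a functional assay on HEK293 cells for agonist activity at G-protein coupled receptor 39 (Homo sapiens), read by scintillation proximity assay and inositol phosphate accumulation, with a stated time of 75 min, in the presence of a further agent that is not named here; on this read-out lower numbers stand for an effect already at smaller amounts and higher numbers for an effect only at larger amounts of compound. Compound 1 `C/C(=N\NC(=O)c1cc2ccccc2cc1O)c1ccc(N)cc1` gives 1100 nM, compound 2 `Cc1cc(C)n(CCOC2CC(=O)Nc3c2c(C)nn3-c2ncnc3nc[nH]c23)n1` gives 16 nM, and compound 3 `Cc1nn(-c2ncnc3nc[nH]c23)c2c1C(NC(=O)Cc1cccs1)CC(=O)N2` gives 3 nM. Compound 2 therefore stands second highest of the three: its nearest neighbour is compound 3, its furthest compound 1, both beyond the scatter.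

Compound 4 `Cc1nn(-c2ncnc3nc[nH]c23)c2c1C(C(=O)N(C)c1nccs1)CC(=O)N2` is not yet measured. Relative to compound 2 the change is a group of 9 heavy atoms (5 carbon, 2 nitrogen, 1 oxygen, 1 sulfur; one five-membered aromatic ring with 2 hetero atoms) in place of a group of 10 heavy atoms (7 carbon, 2 nitrogen, 1 oxygen; one five-membered aromatic ring with 2 hetero atoms), on a saturated ring carbon, the methyl(1,3-thiazol-2-yl)carbamoyl group entering on the saturated ring carbon of the six-membered non-aromatic ring.

Among the measured compounds shown here, only one measured step touches this position: a 5.3-fold lower number from compound 2 to compound 3 (0.73 log units; beyond the scatter). There a group of 9 heavy atoms holding one five-membered aromatic ring with a sulfur replaced the same 10-atom group on the same saturated ring carbon, and the number fell. For the measured compounds named here, compound 4 carries a group of like size with a five-membered aromatic ring of two hetero atoms and a double bond outside aromatic rings, but no step shows this exact group, so the direction is taken from compound 3 with a wider range.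

Compound 4 is expected to give 8 nM in this assay, between 2 nM and 40 nM, a step of a 2.0-fold lower number from compound 2 to compound 4 (0.30 log units; within the scatter).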

Compound 4, half-maximal effective concentration: 18 nM
Estimate against measurement, compound 4: 2.3-fold (0.35 log units) below, and the stated range covers the measured number.
By their numbers in this assay, from the lowest: compound 3; then compounds 2 and 4 (each within the scatter of the next); then compound 1.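

In this assay, placing methyl(1,3-thiazol-2-yl)carbamoyl on the saturated ring carbon gives a 1.1-fold higher number from compound 2 to compound 4 (0.05 log units; within the scatter), so this group and the 10-atom group that leaves cannot be told apart here. The other reading is a 6.0-fold higher number from compound 3 to compound 4 (0.78 log units; beyond the scatter): at this same carbon, a group of like size carrying a sulfur-containing five-membered aromatic ring does not by that feature alone reproduce the number of compound 3, and the position separates methyl(1,3-thiazol-2-yl)carbamoyl from (((thiophen-2-yl)methyl)carbonyl)amino. No measurement at hand accounts for that difference between the two groups.

Going by these compounds, the two groups differ in several features at once, so it remains open whether the step follows from the thiophene against the thiazole, from the order of carbonyl and nitrogen in the link, or from the methyl on the amide nitrogen. The compounds shown also leave open how this carbon responds to a simple amine or a carboxylic acid, or to a phenyl ring in place of the thiophene in the group of compound 3.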